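Methyl on the Phenyl Ring of Two Coumarin-Pyrazole Diesters

The source may hold more compounds than are shown below. What is called first, only, known or untested is meant among the compounds shown, and "the series" means these compounds.

The study compares four compounds that share a core and differ in the ester groups and in one ring substituent. Compound 1 `CCOC(=O)c1c(-c2cc3ccccc3oc2=O)nn(-c2ccccc2)c1C(=O)OCC` carries diethyl esters, and in a functional assay on A549 cells (Homo sapiens) for cytotoxicity, read by MTT assay, with a stated time of 48 h (a higher number here means a weaker inhibitor, a lower number a stronger inhibitor), compound 1 gives 100000 nM. Compound 3 `CCOC(=O)c1c(-c2cc3ccccc3oc2=O)nn(-c2cccc(C)c2)c1C(=O)OCC` differs from it only by methyl in place of hydrogen on an aromatic carbon, and in this assay compound 3 gives 52000 nM; the step of a 1.9-fold lower number from compound 1 to compound 3 (0.28 log units; within the scatter) is small. Compound 2 `COC(=O)c1c(-c2cc3ccccc3oc2=O)nn(-c2ccccc2)c1C(=O)OC` carries dimethyl esters instead; how its core differs from that of compound 1 is not broken down here. In this assay compound 2 gives 28000 nM, the lowest of the three numbers, though its gap to compound 3 lies within the scatter and only its gap to compound 1 lies beyond it.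

Compound 4 `COC(=O)c1c(-c2cc3ccccc3oc2=O)nn(-c2cccc(C)c2)c1C(=O)OC` is not yet measured. It differs from compound 2 by methyl in place of hydrogen on an aromatic carbon, the same change that separates compound 1 from compound 3. Going by the values given here, on the dimethyl core the same change is expected to give a step of about a 1.8-fold lower number from compound 2 to compound 4 (0.24 log units; within the scatter) in this assay, resting on the single earlier step of a 1.9-fold lower number from compound 1 to compound 3 (0.28 log units; within the scatter), which was within the scatter. Because compound 2 already gives 28000 nM, compound 4 is expected to give about 16000 nM in this assay, with a plausible range from 7000 nM to 40000 nM.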

Compound 4, half-maximal inhibitory concentration: 51000 nM
Compound 4: the middle estimate sits 3.2-fold (0.50 log units) below what was measured; the measured number lies above the stated range.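

On the dimethyl core, the change from phenyl to 3-methylphenyl gives a 1.8-fold higher number from compound 2 to compound 4 (0.26 log units; within the scatter) in this assay. Set beside the same change on the diethyl core, this step points the other way, and the gap between the two steps is larger than two such steps would be expected to scatter, so in this pair of cores the methyl does not carry over as a fixed increment: the same change on two cores in this assay, a 1.9-fold lower number (0.28 log units; within the scatter) from compound 1 to compound 3 and a 1.8-fold higher number (0.26 log units; within the scatter) from compound 2 to compound 4, 3.5-fold (0.54 log units) apart, beyond the scatter of two such steps Each step taken alone still lies within the scatter, so neither core by itself shows that the methyl changes the read-out, and two pairs cannot show why the steps part or whether the result reflects a real dependence on the ester groups rather than a chance combination of two small steps.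

The compounds shown leave open how a methoxy group, a chlorine atom or an amine would behave in place of the methyl on each of the two cores. They also leave open whether the steps would part in the same way with a longer ester chain such as propyl, or with a carboxylic acid in place of the esters.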